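Nitro for methyl on the sulfonyl ring: expected cytotoxicity

A few compounds are considered here, and "the series" means these few. Any claim that something is new, unique, unknown or untested is made for them only; others in the source may bear on it.

Compound 1 `Cc1ccc(S(=O)(=O)N2C/C(=C\c3cccnc3)C(=O)/C(=C/c3ccccc3C(F)(F)F)C2)cc1` gives 2930 nM in a functional assay on HepG2 cells (Homo sapiens) for cytotoxicity, read by MTT assay, with a stated time of 24 h; a lower number here means a stronger inhibitor, a higher number a weaker inhibitor. Compound 2 `O=C1/C(=C/c2cccnc2)CN(S(=O)(=O)c2ccc([N+](=O)[O-])cc2)C/C1=C\c1ccccc1C(F)(F)F` differs from compound 1 by nitro in place of methyl on an aromatic carbon, and in this assay compound 2 gives 9370 nM, a step of a 3.2-fold higher number from compound 1 to compound 2 (0.50 log units; beyond the scatter). Compound 3 `Cc1ccc(S(=O)(=O)N2C/C(=C\c3ccncc3)C(=O)/C(=C/c3ccccc3C(F)(F)F)C2)cc1` differs from compound 1 in its core by pyridin-4-yl in place of pyridin-3-yl on a double-bonded chain carbon bound to a double-bonded ring carbon; in this assay compound 3 gives 4640 nM, and the step is a 1.6-fold higher number from compound 1 to compound 3 (0.20 log units; within the scatter). Compound 4 `O=C1/C(=C/c2ccncc2)CN(S(=O)(=O)c2ccc([N+](=O)[O-])cc2)C/C1=C\c1ccccc1C(F)(F)F` has not yet been measured. It differs from compound 3 by nitro in place of methyl on an aromatic carbon, the same change as that from compound 1 to compound 2, at a place described in the same words. The step is expected to be a 3.0-fold higher number from compound 3 to compound 4 (0.48 log units; beyond the scatter). This expectation rests only on compound 1 and compound 2, whose step was a 3.2-fold higher number from compound 1 to compound 2 (0.50 log units; beyond the scatter), the change occurring just twice among these compounds. Compound 4 is therefore estimated at 14000 nM in this assay, between 7000 nM and 28000 nM.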

Compound 4, half-maximal inhibitory concentration: 13400 nM
The estimate for compound 4 lay 1.0-fold (0.02 log units) above the measured number; the range from low to high includes it.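

With nitro in place of methyl, this assay gave a 2.9-fold higher number from compound 3 to compound 4 (0.46 log units; beyond the scatter), and this step matches the earlier one on the other core: the same change on two cores in this assay, a 3.2-fold higher number (0.50 log units; beyond the scatter) from compound 1 to compound 2 and a 2.9-fold higher number (0.46 log units; beyond the scatter) from compound 3 to compound 4, 1.1-fold (0.04 log units) apart, within the scatter of two such steps. With pyridin-4-yl in place of pyridin-3-yl, the reading was a 1.4-fold higher number from compound 2 to compound 4 (0.16 log units; within the scatter), and this change also carried across: the same change on two cores in this assay, a 1.6-fold higher number (0.20 log units; within the scatter) from compound 1 to compound 3 and a 1.4-fold higher number (0.16 log units; within the scatter) from compound 2 to compound 4, 1.1-fold (0.04 log units) apart, within the scatter of two such steps. Across these four compounds, each change therefore behaved alike on both cores, but this rests on just two pairs per change in a single cytotoxicity assay and shows nothing about other cores or other groups.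

The compounds shown leave open how an amine or a carboxylic acid would read in place of methyl or nitro on the sulfonyl ring. They also leave open whether either step would hold if a group such as methoxy replaced trifluoromethyl.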